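Swapping the Sulfonyl Aryl Group: From Compound 2 to Compound 3

A few compounds are considered here, and "the series" means these few. Any claim that something is new, unique, unknown or untested is made for them only; others in the source may bear on it.

Measured so far:
Compound 1, `CC1CCN(C2CCN(S(=O)(=O)c3cn(C)c(=O)n(C)c3=O)CC2)CC1`: > 5000 nM
Compound 2, `Cc1noc(C)c1S(=O)(=O)N1CCC(N2CCC(C)CC2)CC1`: > 5000 nM

Both compounds were tested in a functional assay on DLD-1 cells (Homo sapiens) for antiproliferative activity, read by CellTiter-Glo, with a stated time of 72 h; on this read-out lower numbers stand for stronger inhibition and higher numbers for weaker inhibition. In this assay compound 2 gives > 5000 nM, which is a limit of the assay and not a number. Compound 1 likewise gives only a limit. Compound 2 therefore stands at the limit of > 5000 nM in this assay, at which 2 of the 2 values shown sit; because both values are limits, no order between the two can be stated.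

Compound 3, `CC1CCN(C2CCN(S(=O)(=O)c3cccnc3Cl)CC2)CC1`, differs from compound 2 in a single place: 2-chloropyridin-3-yl in place of 3,5-dimethyl-1,2-oxazol-4-yl on a sulfonyl sulfur. Among the measured compounds shown here, no step between measured compounds is available, so this change has no precedent here. The expected step is a step that the limit leaves unreadable from compound 2 to compound 3, none beyond the usual scatter, since the two neighbouring values already rest at the limit. Compound 3 is expected at 8000 nM, within 2500 nM to 30000 nM, most likely reported again only as a limit.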

Compound 3, half-maximal inhibitory concentration: > 5000 nM
Compound 3: only a limit was reported; the forecaster's own chance of this, stated with the estimate: 75%; the middle value lies beyond the limit too.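

Compound 2 and compound 3 both give only a limit of the assay, so no step between them can be read: the limit of > 5000 nM in this assay, at which 3 of the 3 values shown sit.

The compounds shown leave open whether any group on the sulfonyl sulfur would give a true number rather than a limit.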